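Replacing fluoro with tert-butyl on the aromatic ring

A few compounds are considered here, and "the series" means these few. Any claim that something is new, unique, unknown or untested is made for them only; others in the source may bear on it.

In a functional assay on KB-V1 cells (Homo sapiens) for cytotoxicity, read by MTT assay, with a stated time of 72 h (a higher number here means a weaker inhibitor, a lower number a stronger inhibitor), compound 1 (`CNC(=S)N/N=C1\C(=O)Nc2ccccc21`) gives 19400 nM with a methyl group on an amide-type nitrogen. Compound 2 (`O=C1Nc2ccccc2/C1=N/NC(=S)Nc1cccc(Cl)c1`) gives 640 nM with 3-chlorophenyl there, and compound 3 (`O=C1Nc2ccccc2/C1=N/NC(=S)Nc1ccc(F)cc1`) gives 1920 nM with 4-fluorophenyl, the second highest of the three numbers. Compound 4 (`CC(C)(C)c1ccc(NC(=S)N/N=C2\C(=O)Nc3ccccc32)cc1`) has not yet been measured and differs from compound 3 by tert-butyl in place of fluoro on an aromatic carbon.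

Going by the values given here, no measured pair makes this exact swap. The closest guide is a 3.0-fold higher number from compound 2 to compound 3 (0.48 log units; beyond the scatter) between two substituted phenyl groups, which shows that such a swap can move the number beyond the scatter. Replacing methyl with a substituted phenyl group gave a 30-fold lower number from compound 1 to compound 2 (1.48 log units; beyond the scatter) and a 10-fold lower number from compound 1 to compound 3 (1.00 log units; beyond the scatter) as well. Among the compounds with values here, these steps suggest a modest change in this assay for compound 4, more likely towards a lower number, although no measured compound carries tert-butyl. The expected size is a 2.6-fold lower number from compound 3 to compound 4 (0.41 log units; beyond the scatter) by this estimate. Compound 4 is estimated at 750 nM with an expected range from 220 nM to 2500 nM in this cell test.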

Compound 4, half-maximal inhibitory concentration: 710 nM
Estimate against measurement, compound 4: 1.1-fold (0.02 log units) above, and the stated range covers the measured number.
By their numbers in this assay, from the lowest: compounds 2 and 4 (each within the scatter of the next); then compound 3; then compound 1.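

In this assay, exchanging fluoro, a single heavy atom, for tert-butyl, with 4 heavy atoms, gives a 2.7-fold lower number from compound 3 to compound 4 (0.43 log units; beyond the scatter). The earlier compounds shown here compared only methyl with halogen-bearing phenyl groups, or two such phenyl groups with each other. This step shows that an all-carbon group can replace the halogen on an aromatic carbon, para to a large group, and the number still falls beyond the scatter. No measured evidence is available to explain this step.

The compounds shown leave open how an amine, a carboxylic acid or a longer chain would behave at this same place. They also cannot tell whether the same swap would give a similar step on the core of another compound in the series.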